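The source may report more compounds than this note shows. Statements on the series, on what has been measured and on what is new or still open speak of the compounds shown alone.

In a functional assay on HepG2 cells (Homo sapiens) for inhibition, read by MTT assay, with a stated time of 48 h (on this read-out lower numbers stand for stronger inhibition and higher numbers for weaker inhibition), two compounds that share one core have been measured. Compound 1 (`CCOC(=O)C1=C(N/C=N/c2nnc(S(N)(=O)=O)s2)Nc2[nH]nc(C)c2C1c1ccc(N(C)C)cc1`) gives 38100 nM and compound 2 (`CCOC(=O)C(=NNC1=C(C(=O)OCC)C(c2ccc(N(C)C)cc2)c2c(C)n[nH]c2N1)C(=O)OCC`) gives 80800 nM as the higher of the two numbers, which makes it the weaker inhibitor of the pair. Compound 3 (`CCOC(=O)C1=C(N/N=C(/C(=O)Br)c2ccc(Cl)cc2)Nc2[nH]nc(C)c2C1c1ccc(N(C)C)cc1`) keeps the shared core and differs from compound 2 in one place. The change (a group of 12 heavy atoms (8 carbon, 1 nitrogen, 1 oxygen, 1 chlorine, 1 bromine; one six-membered aromatic ring of carbon only) in place of a group of 12 heavy atoms (7 carbon, 1 nitrogen, 4 oxygen; no ring), on an amine nitrogen) sits on an amine nitrogen and brings in one six-membered aromatic ring of carbon only, where the group that leaves has no ring. Within the data shown here, only one measured step bears on this, a swap of groups on an amine nitrogen that gave a 2.1-fold higher number from compound 1 to compound 2 (0.33 log units; beyond the scatter) in the same read-out. That step was modest, and a single step is thin evidence, so a step of similar or smaller size is expected in this assay and it may not pass the scatter. The direction is uncertain, with a slight lean to a lower number. The expected change is a 1.6-fold lower number from compound 2 to compound 3 (0.21 log units; within the scatter) on this estimate. For compound 3 the estimated value is 50000 nM within an expected range from 15000 nM to 150000 nM for repeated measurements.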

Compound 3, half-maximal inhibitory concentration: 50300 nM
Estimate against measurement, compound 3: 1.0-fold (0.00 log units) below; measured number inside the range.
By their numbers in this assay, from the lowest: compounds 1, 3 and 2 (each within the scatter of the next, the first and the last beyond it).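

In this assay, putting a group with a six-membered aromatic ring of carbon only, plus chlorine and bromine, on this amine nitrogen in place of the ring-free group gives a 1.6-fold lower number from compound 2 to compound 3 (0.21 log units; within the scatter), so the two compounds cannot be told apart. Replacing the group with the five-membered aromatic ring by that same group gives a 1.3-fold higher number from compound 1 to compound 3 (0.12 log units; within the scatter), which also leaves the two compounds inseparable, even though the groups differ in ring type and atom make-up. Among these compounds, the position has now carried three unlike groups, and the only step beyond the scatter is still a 2.1-fold higher number from compound 1 to compound 2 (0.33 log units; beyond the scatter), so compound 3 adds a group that sits within the scatter of both earlier compounds.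

No supporting measurement is available to explain any of these steps. The compounds shown leave open whether a much smaller group on this nitrogen, such as methyl, or an amine at the end of a longer chain would move the number clearly, and whether a carboxylic acid in place of the bromine-bearing carbonyl would change anything.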